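The source may hold more compounds than are shown below. What is called first, only, known or untested is meant among the compounds shown, and "the series" means these compounds.

Measured so far:
compound 1, `C=C(C)[C@H]1CC=C(C)[C@@]2(O)[C@@H]1[C@H](c1ccc(Cl)cc1Cl)O[C@@H]2C(=O)OCC`: 3000 nM
compound 2, `C=C(C)[C@H]1CC=C(C)[C@@]2(O)[C@@H]1[C@H](c1cccc(Cl)c1Cl)O[C@@H]2C(=O)OCC`: 5000 nM

Both compounds were read in a functional assay on KB3 cells (Homo sapiens) for antiproliferative activity, read by MTT assay, with a stated time of 96 h; on this read-out higher numbers stand for weaker inhibition and lower numbers for stronger inhibition. In this assay compound 1 gives 3000 nM and compound 2 gives 5000 nM. Going by the values given here, of the two numbers, that of compound 2 is the highest, but the single step between them, a 1.7-fold higher number from compound 1 to compound 2 (0.22 log units; within the scatter), lies within the scatter, so the two compounds cannot be separated on this read-out.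

Compound 3, `C=C(C)[C@H]1CC=C(C)[C@@]2(O)[C@@H]1[C@H](c1cccc(Br)c1)O[C@@H]2C(=O)OCC`, differs from compound 2 by 3-bromophenyl in place of 2,3-dichlorophenyl on a saturated ring carbon. Among the compounds with values here, the only measured step that bears on this, the change in the dichlorophenyl pattern between compound 1 and compound 2, gave no movement beyond the scatter. Within the data shown here, no measured pair covers the loss of one chlorine or the entry of a bromine, so the data give no direction for this part of the change. The expectation is therefore a step of no size beyond the scatter, a 1.1-fold lower number from compound 2 to compound 3 (0.05 log units; within the scatter), with a wide band around it. For compound 3 the estimate in this assay is 4500 nM, with a range from 1500 nM to 14000 nM.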

Compound 3, half-maximal inhibitory concentration: 3000 nM
Compound 3: middle estimate off by 1.5-fold (0.18 log units), on the high side; the measured number falls inside the stated range.
By their numbers in this assay, from the lowest: compounds 1, 3 and 2 (each within the scatter of the next).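

In this assay, 3-bromophenyl in place of 2,3-dichlorophenyl on the saturated ring carbon gives a 1.7-fold lower number from compound 2 to compound 3 (0.22 log units; within the scatter), and in place of 2,4-dichlorophenyl it gives no change at the digits printed from compound 1 to compound 3 (within the scatter). The earlier step changed only the chlorine pattern, whereas these two also change the halogen, and still neither moves beyond the scatter, so the three aryl groups at this ring carbon, next to the ring oxygen, cannot be separated on this read-out. Nothing available explains why these groups read alike.

All three compounds carry halogen on the phenyl ring, so the flat picture describes only halogen-bearing phenyl groups and says nothing yet about an unsubstituted phenyl, a methoxyphenyl, a phenyl bearing a carboxylic acid or an amine, or a saturated cyclohexyl group at the same carbon. From the compounds shown here alone, it also remains open whether a larger step would appear at this position with any such group, or whether the readings stay within the scatter of one another across a wider range of substituents.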